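An Ethoxycarbonyl Group Replaces Methoxy on Compound 1

The source may report more compounds than this note shows. Statements on the series, on what has been measured and on what is new or still open speak of the compounds shown alone.

Compound 1 `COc1ccc(Nc2ccc3c(c2)C(=O)N(C2CCC(=O)NC2=O)C3=O)cc1` gives 29% in an assay on FRT-Jurkat cells for inhibition of nuclear factor NF-kappa-B complex (Homo sapiens), read by flow cytometry, with a stated time of 24 h, tested at 10 uM; on this read-out higher numbers stand for more inhibition at the one concentration tested (going by the name of the read-out) and lower numbers for less inhibition.
Compound 2 `CCCc1ccc(Nc2cccc3c2C(=O)N(C2CCC(=O)NC2=O)C3=O)cc1` gives 23% in this assay.
Compound 3 `O=C1CCC(N2C(=O)c3ccc(Nc4ccccn4)cc3C2=O)C(=O)N1` gives 9% in this assay.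

Compound 1 stands highest of the three numbers. Compound 2 lies within the scatter of compound 1, so the two cannot be ordered, whereas the step of a number 20 percentage points lower from compound 1 to compound 3 (beyond the scatter) lies beyond it. Compound 4 `CCOC(=O)c1ccc(Nc2ccc3c(c2)C(=O)N(C2CCC(=O)NC2=O)C3=O)cc1` carries ethoxycarbonyl in place of methoxy on an aromatic carbon. Going by the values given here, no measured step exchanges one group for another on that aromatic carbon; the only step that touches the same nitrogen substituent replaces the whole aryl group and is only a modest move. The change to compound 4 is therefore expected to bring a step within the scatter, a number 4 percentage points lower from compound 1 to compound 4 (within the scatter). Compound 4 is estimated at 25% in this assay, within a range from 5% to 45%.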

Compound 4, a percentage reported as inhibition, at one concentration (the size of the read-out at that concentration, not a potency): 5%
Estimate against measurement, compound 4: 20 percentage points above; the measured number falls inside the stated range.
By their numbers in this assay, from the lowest: compounds 4 and 3 (each within the scatter of the next); then compounds 2 and 1 (each within the scatter of the next).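

The earlier compounds shown here showed a change only by replacing the whole aryl group on the nitrogen. This result shows that, with that aryl ring kept, exchanging methoxy for ethoxycarbonyl at the single aromatic carbon para to a large group is enough to give a number 24 percentage points lower from compound 1 to compound 4 (beyond the scatter) in this assay. Nothing available explains this drop. The compounds shown leave open whether the loss follows from the ethoxycarbonyl group as a whole or from only part of it, and how a carboxylic acid, an amine or a longer alkoxy chain on that carbon would read.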